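The compounds below may be only part of what the source reports. "The series", "measured", "known", "first", "only" and "open" are said of these compounds alone.

Compounds measured in a functional assay on BT-549 cells (Homo sapiens) for inhibition, read by sulforhodamine B assay, with a stated time of 48 h; on this read-out higher numbers stand for weaker inhibition of growth and lower numbers for stronger inhibition of growth:
compound 1 `COc1ccc(-c2cc(/C=C/C(=O)c3ccc(N)cc3)[nH]n2)cc1` — 4780 nM
compound 2 `COc1cc(-c2cc(/C=C/C(=O)c3ccc(Cl)c(Cl)c3)[nH]n2)cc(OC)c1OC` — 29300 nM
compound 3 `COc1ccc(C(=O)/C=C/c2cc(-c3cc(OC)c(OC)c(OC)c3)n[nH]2)cc1OC` — 2900 nM

Compound 2 stands highest of the three numbers in this assay, with compound 1 nearest and compound 3 furthest. Compound 4 `COc1cc(-c2cc(/C=C/C(=O)c3ccc(F)c(F)c3)[nH]n2)cc(OC)c1OC` is not yet measured; it differs from compound 2 in one place: 3,4-difluorophenyl in place of 3,4-dichlorophenyl on a carbonyl carbon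

Among the measured compounds shown here, the single measured step bearing on this position is a 10-fold lower number from compound 2 to compound 3 (1.00 log units; beyond the scatter), in which the group on the carbonyl carbon was replaced outright. For compound 4 the change stays with a halogenated ring, so only part of that movement, if any, is expected, in the same downward direction. The estimated number for compound 4 is 15000 nM (range 5000 nM to 50000 nM), an expected step of a 2.0-fold lower number from compound 2 to compound 4 (0.29 log units; within the scatter).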

Compound 4, concentration for total growth inhibition: 19300 nM
Compound 4: middle estimate off by 1.3-fold (0.11 log units), on the low side; measured number inside the range.
By their numbers in this assay, from the lowest: compounds 3 and 1 (each within the scatter of the next); then compounds 4 and 2 (each within the scatter of the next).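

In this assay the exchange of one halogenated ring for the other on the carbonyl carbon gives a 1.5-fold lower number from compound 2 to compound 4 (0.18 log units; within the scatter) and so separates chlorine from fluorine at this position by no more than the scatter. The 3,4-dimethoxyphenyl group stands apart from the 3,4-difluorophenyl group as well as from the 3,4-dichlorophenyl group, with a 6.7-fold higher number from compound 3 to compound 4 (0.82 log units; beyond the scatter) as the new measure of that gap. No measured evidence accounts for this difference. Still open, from the compounds shown here alone, is how a ring bearing a carboxylic acid or a nitrile on the carbonyl carbon would compare, with the rest of compound 4 unchanged.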